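The source may report more compounds than this note shows. Statements on the series, on what has been measured and on what is new or still open speak of the compounds shown alone.

Measured in a functional assay on PC-3 cells (Homo sapiens) for inhibition, read by sulforhodamine B assay, with a stated time of 48 h; a higher number here means a weaker inhibitor, a lower number a stronger inhibitor:
compound 1 `O=C(Nc1cccc(-n2cc(-c3ccncc3)c(-c3cc(O)cc(Cl)c3)n2)c1)Nc1ccc(Cl)c(Cl)c1` gives 1690 nM;
compound 2 `COc1cc(Cl)cc(-c2nn(-c3cccc(NC(=O)Nc4ccc(Cl)c(C(F)(F)F)c4)c3)cc2-c2ccncc2)c1` gives 340 nM;
compound 3 `COc1cc(Cl)cc(-c2nn(-c3cccc(NC(=O)Nc4cc(C(F)(F)F)cc(C(F)(F)F)c4)c3)cc2-c2ccncc2)c1` gives 300 nM.

Compound 1 stands highest of the three numbers, and its gaps to compound 2 and to compound 3 both lie beyond the scatter, so among these it is the weakest inhibitor. Compound 4 `COc1cc(Cl)cc(-c2nn(-c3cccc(NC(=O)Nc4ccc(Cl)c(Cl)c4)c3)cc2-c2ccncc2)c1` has not been measured. It differs from compound 1 by methyl in place of hydrogen on an oxygen on an aromatic ring, hydroxy to methoxy, giving 3-chloro-5-methoxyphenyl. Compound 2 and compound 3 both carry that methoxy group, though they differ from compound 1 elsewhere as well, and both show lower numbers in this assay. Among the compounds with values here, no single-change pair is measured, so the step is uncertain; a drop of moderate size, beyond the scatter, is expected, a 3.8-fold lower number from compound 1 to compound 4 (0.57 log units; beyond the scatter). Compound 4 is estimated at 450 nM, with a range from 200 nM to 1200 nM.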

Compound 4, half-maximal inhibitory concentration: 1130 nM
Beside the measured number, compound 4's estimate is 2.5-fold (0.40 log units) below it; the measured number falls inside the stated range.
By their numbers in this assay, from the lowest: compounds 3 and 2 (each within the scatter of the next); then compounds 4 and 1 (each within the scatter of the next).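

Changing hydroxy to methoxy on the 3-chloro-5-hydroxyphenyl group, now seen as a single change, gives a 1.5-fold lower number from compound 1 to compound 4 (0.17 log units; within the scatter), so in this assay this position does not separate the two groups. The step that does exceed the scatter is the other change, chloro in place of trifluoromethyl on an aromatic carbon, with a 3.3-fold higher number from compound 2 to compound 4 (0.52 log units; beyond the scatter). No evidence is at hand to explain either step.

From the compounds shown here alone, whether an ethoxy group or an amine at this position would differ from hydroxy and methoxy remains open. So does whether the trifluoromethyl step holds when hydroxy replaces methoxy.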